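The compounds below may be only part of what the source reports. "The series", "measured", "known", "first", "only" and "open" are said of these compounds alone.

Measured in a functional assay on SK-BR-3 cells (Homo sapiens) for antiproliferative activity; on this read-out lower numbers stand for stronger inhibition and higher numbers for weaker inhibition:
- Compound 1 `CCCCCCC(=O)Nc1cc2ccc(O[C@@H]3OC(C)(C)[C@H](OC)[C@@H](O)[C@H]3O)c(C)c2oc1=O`: 58300 nM
- Compound 2 `CCCCCC(=O)Nc1cc2ccc(O[C@@H]3OC(C)(C)[C@H](OC)[C@@H](O)[C@H]3O)c(C)c2oc1=O`: 84000 nM

Compound 1 and compound 2 stand level, within the scatter of each other, so neither can be ranked ahead. Compound 3 `CO[C@@H]1[C@@H](O)[C@@H](O)[C@H](Oc2ccc3cc(NC(=O)C4CCC4)c(=O)oc3c2C)OC1(C)C` changes the same part of the molecule: cyclobutyl in place of hexyl on a carbonyl carbon. In short, cyclobutyl sits in place of hexyl on a carbonyl carbon.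

For the measured compounds named here, only one measured step touches this group: a 1.4-fold higher number from compound 1 to compound 2 (0.16 log units; within the scatter), with hydrogen in place of methyl on the saturated chain. That step stayed within the scatter, but no ring was involved, so it is only a weak guide here. No step beyond the scatter is therefore expected in this assay, in either direction. The estimated step is a 1.2-fold higher number from compound 1 to compound 3 (0.08 log units; within the scatter). For compound 3 the expected value is 70000 nM, with an estimated range from 28000 nM to 170000 nM.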

Compound 3, half-maximal inhibitory concentration: 220000 nM
Compound 3: middle estimate off by 3.1-fold (0.50 log units), on the low side; the whole stated range lies below it.
By their numbers in this assay, from the lowest: compounds 1 and 2 (each within the scatter of the next); then compound 3.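

In this assay, the group on this carbonyl carbon can clearly shift the read-out. Hexyl and pentyl could not be told apart, but cyclobutyl in their place gives a 3.8-fold higher number from compound 1 to compound 3 (0.58 log units; beyond the scatter) and a 2.6-fold higher number from compound 2 to compound 3 (0.42 log units; beyond the scatter), both beyond the scatter, so this position does not accept every carbon group equally. Nothing measured here explains this weakening.

Cyclobutyl differs from hexyl in two ways at once, with fewer carbons and a ring in place of an open chain, and the compounds shown cannot separate these two changes. As far as these compounds go, a straight butyl chain and a cyclohexyl ring on the same carbonyl carbon would each change only one of them, while a longer chain or an amine on that chain remains open too.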